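Shortening the sulfonyl chain and adding a fluorine

The source may report more compounds than this note shows. Statements on the series, on what has been measured and on what is new or still open speak of the compounds shown alone.

Of the compounds shown here, two have been measured. Compound 1 `CS(=O)(=O)c1ccc(Nc2ncnc(N3CCC(c4nc(-c5cccnc5)no4)CC3)c2[N+](=O)[O-])cc1` gives 660 nM in a functional assay for agonist activity at Glucose-dependent insulinotropic receptor (Homo sapiens); on this read-out lower numbers stand for an effect already at smaller amounts and higher numbers for an effect only at larger amounts of compound. Compound 2 `CCCS(=O)(=O)c1ccc(Nc2ncnc(N3CCC(c4nc(C(C)C)no4)CC3)c2[N+](=O)[O-])cc1` gives 4.7 nM in this assay, the lowest of the two numbers and a gap from compound 1 that lies beyond the scatter. Compound 1 and compound 2 differ in more than one place at once, so their two values show only that the whole set of changes brings a large shift, not what each change alone contributes.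

Compound 3 `CC(C)c1noc(C2CCN(c3ncnc(Nc4ccc(S(C)(=O)=O)c(F)c4)c3[N+](=O)[O-])CC2)n1` has not yet been measured. Compared with compound 2 it carries 3-fluoro-4-(methylsulfonyl)phenyl in place of 4-(propylsulfonyl)phenyl on a nitrogen on an aromatic ring. Part of this change, a methylsulfonyl in place of a propylsulfonyl, points back toward what compound 1 carries, while the fluorine is new to the series.

Going by the values given here, since no single-change step is available, the direction is uncertain; a modest step upward in this assay from compound 2 to compound 3 of about a 3.2-fold higher number from compound 2 to compound 3 (0.50 log units; beyond the scatter) is expected. Compound 3 is expected to give about 15 nM in this assay, with a likely range from 3 nM to 80 nM.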

Compound 3, half-maximal effective concentration: 3.4 nM
The estimate for compound 3 lay 4.4-fold (0.64 log units) above the measured number, and the stated range covers the measured number.
By their numbers in this assay, from the lowest: compounds 3 and 2 (each within the scatter of the next); then compound 1.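

In this assay, exchanging 4-(propylsulfonyl)phenyl for 3-fluoro-4-(methylsulfonyl)phenyl gives a 1.4-fold lower number from compound 2 to compound 3 (0.14 log units; within the scatter), so the read-out does not separate these two groups. Going by these compounds alone, this is the first pair that differs in only one place, and it shows that this position tolerates this exchange of whole groups without a shift beyond the scatter. It also shows that a methylsulfonyl group can be present in a compound with a low number, as compound 3 gives 3.4 nM while carrying one, and no measurement at hand offers an explanation for this outcome.

The exchange shortens the sulfonyl chain and adds a fluorine at once, so the two parts could each have little effect or could offset each other, and this single step cannot distinguish these cases. As far as these compounds go, it also remains open how this assay would respond to a different group on this ring, such as a chlorine in place of the fluorine or an ethylsulfonyl chain in place of the methylsulfonyl.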